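The compounds below may be only part of what the source reports. "The series", "measured", "known", "first", "only" and "open" are said of these compounds alone.

Three compounds have been measured in a physicochemical assay for lipophilicity, at pH 7.4; a lower number here means a more polar compound, a higher number a more lipophilic compound:

compound 1, `Cc1ccc(N(CC(C)C)S(=O)(=O)c2ccc3c(c2)C(=O)CC(C2CCOCC2)O3)c(C)c1`, gives 4.28
compound 2, `Cc1ccc(N(C2CCC2)S(=O)(=O)c2ccc3c(c2)C(=O)CC(C2CCOCC2)O3)c(C)c1`, gives 3.86
compound 3, `CCc1ccc(N(CC(C)C)S(=O)(=O)c2ccc3c(c2)C(=O)CC(C2CCOCC2)O3)cc1`, gives 4.21

Compound 1 and compound 2 share a core and differ in one place: cyclobutyl in place of isobutyl on a sulfonamide nitrogen. That change produced a number 0.42 log units lower from compound 1 to compound 2 (beyond the scatter). Compound 3 differs from compound 1 in a different place, namely (4-ethylphenyl in place of 2,4-dimethylphenyl on a sulfonamide nitrogen), and that change produced a number 0.07 log units lower from compound 1 to compound 3 (within the scatter), so in this assay compound 1 and compound 3 cannot be told apart.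

Compound 4, `CCc1ccc(N(C2CCC2)S(=O)(=O)c2ccc3c(c2)C(=O)CC(C2CCOCC2)O3)cc1`, has not yet been measured in this assay. It stands to compound 3 as compound 2 stands to compound 1: cyclobutyl in place of isobutyl on a sulfonamide nitrogen. The place of the change is described in the same words for both pairs, so this is the same change made on a core that differs only as stated above. Since the core difference left the value unchanged within the scatter, compound 3 is expected to behave like compound 1 here, and the step from compound 3 to compound 4 is expected to be of about the size seen from compound 1 to compound 2, that is a number 0.41 log units lower from compound 3 to compound 4 (beyond the scatter). On that basis compound 4 is estimated to give 3.8 in this assay, with a likely range from 3.55 to 4.05.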

Compound 4, distribution coefficient: 3.78
The estimate for compound 4 lay 0.02 log units above the measured number; the range from low to high includes it.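

In this assay, cyclobutyl in place of isobutyl on a sulfonamide nitrogen gave a number 0.43 log units lower from compound 3 to compound 4 (beyond the scatter), a step of much the same size as a number 0.42 log units lower from compound 1 to compound 2 (beyond the scatter), so the change carried over between these two cores, which differ only in 4-ethylphenyl against 2,4-dimethylphenyl. The fourth side of the square agrees: the same swap of the aryl group gave a number 0.08 log units lower from compound 2 to compound 4 (within the scatter), so it separates the cyclobutyl pair no more than it separates the isobutyl pair in this assay. This is a single transfer between two closely alike cores, so it shows that the step held here but not that it would hold on a core that differs more, and nothing available bears on why the step has this size.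

All four compounds carry only isobutyl or cyclobutyl on the sulfonamide nitrogen, and only methyl or ethyl groups on the phenyl ring there. From the compounds shown here alone, it remains open whether the step would keep its size with an amine or a carboxylic acid in place of the ethyl group, and what a longer chain than isobutyl on that nitrogen would give.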